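This account rests on a few compounds, and the source may have more. Where it says the series, first, only, none or still open, it means among the compounds named here.

Measured so far:
Compound 1, `Cc1cc(F)c(CNc2ncc(-c3cccnc3C)c3nncn23)c2c1OCC2`: "not determined" (no result reported)
Compound 2, `Cc1ncccc1-c1cnc(NCc2c(F)cc(F)c3c2CCO3)n2cnnc12`: 2.6

Compound 1, `Cc1cc(F)c(CNc2ncc(-c3cccnc3C)c3nncn23)c2c1OCC2`, has no single number in a physicochemical assay for lipophilicity, using the shake flask method, in phosphate buffer, measured as octanol-water partition, at pH 7.4; on this read-out higher numbers stand for higher lipophilicity and lower numbers for lower lipophilicity; its result is recorded as "not determined" (no result reported), so there is nothing to place it on the scale. The closest point of reference is compound 2, `Cc1ncccc1-c1cnc(NCc2c(F)cc(F)c3c2CCO3)n2cnnc12`, which in this assay gives 2.6. Within the data shown here, no step between two measured compounds is given here, so the size of any change along this series is not known from measurement.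

The step under consideration leads from compound 1 to compound 3, `Cc1ncccc1-c1cnc(NCc2c(F)cc(N)c3c2CCO3)n2cnnc12`. The change is amino in place of methyl on an aromatic carbon. Among the measured compounds shown here, since no measured pair of this kind exists here, the expectation for this assay rests on the nature of the swap alone: a step downward, larger than the usual scatter, is expected, with the lipophilicity of compound 3 ending up lower than what the value of compound 2 suggests for this core. Compound 3 is therefore expected to give about 1.5, within a range from 0.9 to 2.1.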

Compound 3, distribution coefficient: 1.8
Compound 3: the middle estimate sits 0.30 log units below what was measured; low and high end bracket the measured number.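

In this assay the swap of fluoro for amino on this aromatic carbon gives a number 0.80 log units lower from compound 2 to compound 3 (beyond the scatter) and so provides the first measured size for a change at this place in the series. Among these compounds, the step from methyl to amino itself cannot be read: compound 1 has no number, which leaves the fluoro-to-amino pair as the only measured comparison at this carbon. Nothing available here accounts for the size of this step.

Where methyl on this carbon would fall relative to fluoro and amino in this assay remains open, and so does the question of how a hydroxyl, a methoxy or a dimethylamino group at the same place would compare with them. A single pair also cannot show whether amino in place of fluoro would bring a similar step on a different core, or at another aromatic carbon of this one.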